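Fluoro for Hydrogen on the Shared Core of Compound 1

The source may hold more compounds than are shown below. What is called first, only, known or untested is meant among the compounds shown, and "the series" means these compounds.

Compound 1 `CCCNNC(=O)c1ccc(CNC(=O)c2cc3ccccc3o2)cc1` was tested in an assay on isolated protein for inhibition of protein deacetylase HDAC6 (Homo sapiens), read by fluorescence, with a stated time of 2 h; on this read-out lower numbers stand for stronger inhibition and higher numbers for weaker inhibition. In this assay compound 1 gives only a limit, > 10000 nM, and not a number. Compound 2 `CCCNNC(=O)c1ccc(CNC(=O)c2cc3ccccc3s2)cc1` likewise gives only a limit in this assay, > 10000 nM. Compound 3 `CCCNNC(=O)c1ccc(CNC(=O)c2cc3cc(Cl)ccc3[nH]2)cc1` also stops at a limit in this assay, > 10000 nM. All three results sit at the limit of > 10000 nM in this assay, at which 3 of the 3 values shown sit, so compound 1 stands exactly where its two companions stand, and the numbers shown separate none of them. Among the compounds with values here, no step between measured compounds that differ in a single place is available here.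

Compound 4 `CCCNNC(=O)c1ccc(CNC(=O)c2cc3cc(F)ccc3o2)cc1` has not yet been measured in this assay. It differs from compound 1 by fluoro in place of hydrogen on an aromatic carbon. Within the data shown here, with every measured compound resting at the limit, the data give no direction for this step. Compound 4 is therefore expected to remain at or near the limit, with an estimated value of 15000 nM and a range of 5000 nM to 50000 nM. The step that this estimate means, a step that the limit leaves unreadable from compound 1 to compound 4, is expected to lie within the scatter.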

Compound 4, half-maximal inhibitory concentration: > 10000 nM
Compound 4: no number, only a limit; the forecaster's own chance of this, stated with the estimate: 85%; the middle value does not contradict the limit.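

In this assay, within the data shown here, compound 4 gives only a limit of > 10000 nM and so, set against compound 1, it yields no step that can be read: the limit of > 10000 nM in this assay, at which 4 of the 4 values shown sit.

The compounds shown leave open how far compound 1 and compound 4 truly differ, and whether any change on the shared core would give a number in this assay rather than a limit.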